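Changing the anilide ring in a dopamine receptor agonist series

The source may report more compounds than this note shows. Statements on the series, on what has been measured and on what is new or still open speak of the compounds shown alone.

Compound 1 `CCc1cccc(NC(=O)CN2CCC(c3cccc[n+]3[O-])CC2)c1`: 95 nM
Compound 2 `Cc1cccc(NC(=O)CN2CCC(c3nccs3)CC2)c1`: 1 nM
Compound 3 `Cc1cccc(C(=O)NCN2CCC(c3ccccn3)CC2)c1`: 9 nM

All three were tested in a functional assay on HEK293 cells for agonist activity at D(4) dopamine receptor (Homo sapiens), read by FLIPR; on this read-out higher numbers stand for an effect only at larger amounts of compound and lower numbers for an effect already at smaller amounts. Compound 1 stands at the highest number of the three with 95 nM; compound 3 gives 9 nM and compound 2 gives 1 nM, each lying beyond the scatter from compound 1. Compound 4 `O=C(CN1CCC(c2cccc[n+]2[O-])CC1)Nc1cccc(Cl)c1Cl` has not yet been measured in this assay. It differs from compound 1 in one place: 2,3-dichlorophenyl in place of 3-ethylphenyl on an amide-type nitrogen. For the measured compounds named here, no measured pair shows this change, so its size cannot be read off from the data at hand. The step of a 1.6-fold lower number from compound 1 to compound 4 (0.20 log units; within the scatter) is expected to be modest, most likely a lowering of the number, though one that may still fall within the scatter. Compound 4 is expected to give about 60 nM, within a range from 15 nM to 250 nM.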

Compound 4, half-maximal effective concentration: 180 nM
Beside the measured number, compound 4's estimate is 3.0-fold (0.48 log units) below it; low and high end bracket the measured number.
By their numbers in this assay, from the lowest: compound 2; then compound 3; then compounds 1 and 4 (each within the scatter of the next).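

In this assay, 2,3-dichlorophenyl in place of 3-ethylphenyl on an amide-type nitrogen gives a 1.9-fold higher number from compound 1 to compound 4 (0.28 log units; within the scatter). For the compounds shown here, this is the first measured pair at this position, and it shows that this exchange of one aryl group for another, at equal heavy-atom count, leaves the two compounds indistinguishable on this read-out. Nothing at hand accounts for this result. The compounds shown leave open whether an unsubstituted phenyl or a phenyl carrying a methoxy group or an amine would also stay within the scatter of compound 1. They also leave open whether the same exchange behaves alike on the core of compound 2.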